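Swapping an isopropoxy for a chlorophenoxy on the shared core

The compounds below may be only part of what the source reports. "The series", "measured", "known", "first", "only" and "open" are said of these compounds alone.

Measured compounds:
- compound 1, `CCc1cc(C)c(C(=O)N=C(N)N)cc1S(C)(=O)=O`, 4.8 nM
- compound 2, `Cc1cc(-c2ccc(Cl)cc2Cl)c(S(C)(=O)=O)cc1C(=O)N=C(N)N`, 42 nM
- compound 3, `Cc1cc(OC(C)C)c(S(C)(=O)=O)cc1C(=O)N=C(N)N`, 19 nM

All three share one core and differ only at a single aromatic carbon. In a functional assay for inhibition of sodium/hydrogen exchanger (Oryctolagus cuniculus) (on this read-out higher numbers stand for weaker inhibition and lower numbers for stronger inhibition), compound 1 gives 4.8 nM, the lowest number of the three. Compound 3 stands second highest: a 2.2-fold lower number from compound 2 to compound 3 (0.34 log units; beyond the scatter) separates it from compound 2, and a 4.0-fold higher number from compound 1 to compound 3 (0.60 log units; beyond the scatter) from compound 1.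

Compound 4, `Cc1cc(Oc2ccc(Cl)cc2)c(S(C)(=O)=O)cc1C(=O)N=C(N)N`, is not yet measured. It differs from compound 3 in one place: 4-chlorophenyl in place of isopropyl on an oxygen on an aromatic ring. The most informative measured steps are those in which a small alkyl group gives way to a chlorinated aryl group, as in an 8.8-fold higher number from compound 1 to compound 2 (0.94 log units; beyond the scatter), and the smaller return step a 2.2-fold lower number from compound 2 to compound 3 (0.34 log units; beyond the scatter). Both point the same way: the aryl-bearing compounds give higher numbers than the alkyl-bearing ones. Since compound 4 also gains a chlorinated aryl ring, though here on an oxygen, a modest rise is expected, a 2.1-fold higher number from compound 3 to compound 4 (0.32 log units; beyond the scatter). Compound 4 is therefore estimated at 40 nM in this assay, with a likely range from 15 nM to 110 nM.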

Compound 4, half-maximal inhibitory concentration: 13 nM
Compound 4: the middle estimate sits 3.1-fold (0.49 log units) above what was measured; measured number below the stated range.
By their numbers in this assay, from the lowest: compound 1; then compounds 4 and 3 (each within the scatter of the next); then compound 2.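

Replacing isopropyl on the oxygen with 4-chlorophenyl puts an aromatic ring at this position, yet in this assay it gives a 1.5-fold lower number from compound 3 to compound 4 (0.16 log units; within the scatter), so the two compounds cannot be told apart. A chlorinated aromatic ring therefore does not by itself raise the number, as 4-chlorophenoxy in place of 2,4-dichlorophenyl gives a 3.2-fold lower number from compound 2 to compound 4 (0.51 log units; beyond the scatter), although this step changes both the oxygen link and the chlorine pattern at once. Ethyl still gives the lowest number, with 4-chlorophenoxy in its place giving a 2.7-fold higher number from compound 1 to compound 4 (0.43 log units; beyond the scatter).

The data offer no independent measurement that explains these differences. On these data alone, it remains open whether a plain phenoxy, a phenoxy ring carrying an amine or a carboxylic acid, or a longer chain on the oxygen would follow compound 3 and compound 4 or move closer to compound 1.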